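The compounds below may be only part of what the source reports. "The series", "measured", "known", "first", "only" and "open" are said of these compounds alone.

The three measured compounds and their values in an ADME assay on Vero cells (Chlorocebus sabaeus) for cytotoxicity (a lower number here means that less compound is tolerated, a higher number that more compound is tolerated), are:

Compound 1, `CCN(CC)CN1C(=O)/C(=N/NC(=S)Nc2ccc(OC)cc2)c2ccccc21`, gives 4000 nM.
Compound 2, `CCN(CC)CN1C(=O)/C(=N/NC(=S)Nc2ccc(C)cc2)c2ccccc21`, gives 100000 nM.
Compound 3, `CCN(CC)CN1C(=O)/C(=N/NC(=S)Nc2ccc(OC)cc2)c2cc(Cl)ccc21`, gives 4000 nM.

Compound 1 and compound 2 share one core and differ in a single place: methyl in place of methoxy on an aromatic carbon. That change made a large step, a 25-fold higher number from compound 1 to compound 2 (1.40 log units; beyond the scatter). Compound 3 carries a different core; the difference between the two cores is chloro in place of hydrogen on an aromatic carbon, and across it the number stayed put, no change at the digits printed from compound 1 to compound 3 (within the scatter). Compound 3 therefore stands level with compound 1, the two together forming the lowest pair of the three numbers, with compound 2 furthest away.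

Compound 4, `CCN(CC)CN1C(=O)/C(=N/NC(=S)Nc2ccc(C)cc2)c2cc(Cl)ccc21`, has not yet been measured in this assay. Within the data shown here, it differs from compound 3 by methyl in place of methoxy on an aromatic carbon, which is the same change as the one separating compound 1 from compound 2, since the surroundings of the place are described in identical words. This change has been measured only once among these compounds, so the expectation rests on that single step. Because the change gave a 25-fold higher number from compound 1 to compound 2 (1.40 log units; beyond the scatter), and because compound 3 starts from 4000 nM, level with compound 1, a step of similar size is expected. For compound 4 the expected step is a 25-fold higher number from compound 3 to compound 4 (1.40 log units; beyond the scatter). The estimate for compound 4 is thus 100000 nM, with a range from 40000 nM to 250000 nM.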

Compound 4, minimum cytotoxic concentration: >= 4000 nM
Compound 4 was reported as a limit (the forecaster's own chance of this, stated with the estimate: 10%); the middle value lies beyond the limit too.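

In this assay compound 4 is reported only as a limit, >= 4000 nM, and not as a number. The change from methoxy to methyl gives a number no lower from compound 3 to compound 4 (the limit leaves the size open), and setting it beside the earlier step takes the comparison of the two cores only this far: the same change on two cores in this assay, a 25-fold higher number (1.40 log units; beyond the scatter) from compound 1 to compound 2 and a number no lower (the limit leaves the size open) from compound 3 to compound 4; the limit leaves it open whether they differ. This shows that, on the core carrying chloro, the change did not run against the direction seen on the core of compound 1, but it does not show that the large earlier step carried over in size, nor that it shrank; the step from compound 2 to compound 4 cannot be read either, so the effect of chloro alongside methyl also stays unsized.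

The compounds shown leave open how the series would respond if a group other than methoxy or methyl, such as an amine, a carboxylic acid or a longer chain, stood in the same place on the aromatic ring. They also leave open whether the change would behave the same way on a core carrying something other than hydrogen or chloro, since only these two cores appear here.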